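Naphthyl in place of phenyl on the benzylamine arm

The source may report more compounds than this note shows. Statements on the series, on what has been measured and on what is new or still open speak of the compounds shown alone.

Measured so far:
compound 1 `CC(C)(C)c1ccc(CNCCCNS(=O)(=O)c2cc(C(F)(F)F)cc(C(F)(F)F)c2)cc1` gives 2000 nM
compound 2 `O=S(=O)(NCCCNCc1ccccc1)c1cc(C(F)(F)F)cc(C(F)(F)F)c1` gives 15000 nM

Both compounds were tested in a functional assay on HT-29 cells (Homo sapiens) for inhibition, read by MTT assay, with a stated time of 72 h; a higher number here means a weaker inhibitor of growth, a lower number a stronger inhibitor of growth. Compound 2 holds the highest of the two numbers in this assay, and its nearest neighbour is compound 1, which differs from it only in a tert-butyl group on the aromatic carbon of the benzyl ring; that step, a 7.5-fold higher number from compound 1 to compound 2 (0.88 log units; beyond the scatter), is modest but beyond the scatter, so removing that group weakened growth inhibition.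

Compound 3 `O=S(=O)(NCCCNCc1cccc2ccccc12)c1cc(C(F)(F)F)cc(C(F)(F)F)c1` has not yet been measured. It differs from compound 2 by naphthalen-1-yl in place of phenyl on a saturated chain carbon bound to an amine nitrogen, a change on the same benzylamine arm where compound 1 and compound 2 differ. Going by the values given here, the only step that bears on it is the one from compound 1 to compound 2, which shows that a larger group on that arm goes with a lower number. By analogy compound 3 is expected to give a lower number than compound 2, with a step of about a 3.8-fold lower number from compound 2 to compound 3 (0.57 log units; beyond the scatter) in this assay. The estimate for compound 3 is 4000 nM, within a range of 1500 nM to 12000 nM.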

Compound 3, concentration for 50% growth inhibition: 2600 nM
Compound 3: middle estimate off by 1.5-fold (0.19 log units), on the high side; low and high end bracket the measured number.
By their numbers in this assay, from the lowest: compounds 1 and 3 (each within the scatter of the next); then compound 2.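

In this assay the step of a 5.8-fold lower number from compound 2 to compound 3 (0.76 log units; beyond the scatter) shows that 4-(tert-butyl)phenyl is not the only replacement for phenyl on this saturated chain carbon bound to an amine nitrogen that gives a lower number: naphthalen-1-yl, with its second six-membered aromatic ring of carbon only, does so as well. The comparison of the two larger groups, a 1.3-fold higher number from compound 1 to compound 3 (0.11 log units; within the scatter) and so within the scatter, means that this assay does not separate them, and the three compounds show that two different enlargements of the phenyl group can give numbers within the scatter of each other. No measurement at hand accounts for either the step from phenyl or the match of the two larger groups.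

The compounds shown leave open whether naphthalen-2-yl would match naphthalen-1-yl, and whether a cyclohexyl group or a pyridinyl ring in the same place would keep the lower number. They also leave open what a longer chain linking the amine and the sulfonamide would do with naphthalen-1-yl on this arm.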